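A few compounds are considered here, and "the series" means these few. Any claim that something is new, unique, unknown or untested is made for them only; others in the source may bear on it.

For the measured compounds named here, in a functional assay on MCF7 cells (Homo sapiens) for antiproliferative activity, read by MTT assay, with a stated time of 72 h (on this read-out lower numbers stand for stronger inhibition and higher numbers for weaker inhibition), compound 2 `COc1ccc(N2C(=O)COc3ccc(-c4cnc(OC)c(NS(=O)(=O)c5ccc(F)cc5)c4)cc32)cc1` gives 8260 nM, the only plain number among the three measured compounds. Compound 1 `Cc1ccc(N2C(=O)COc3ccc(-c4cnc5ccccc5c4)cc32)cc1` gives only a limit, > 40000 nM. Compound 3 `O=C1COc2ccc(-c3cnc4ccccc4c3)cc2N1C1CCCCC1` likewise gives only a limit, > 40000 nM. The step that the two limits leave unreadable from compound 1 to compound 3 cannot be sized because the limit of > 40000 nM in this assay, at which 2 of the 3 values shown sit, covers both of its ends.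

Compound 4 `COc1ncc(-c2ccc3c(c2)N(C2CC2)C(=O)CO3)cc1NS(=O)(=O)c1ccc(F)cc1` differs from compound 2 by cyclopropyl in place of 4-methoxyphenyl on an amide-type nitrogen in a ring. Going by the values given here, the one measured step at the same position, cyclohexyl in place of 4-methylphenyl on the amide-type nitrogen, is the unreadable one, so no measured step tells how large a change to expect in this assay, in either direction. Compound 4 is therefore estimated at 15000 nM, with a range from 4000 nM to 40000 nM, an expected step of a 1.8-fold higher number from compound 2 to compound 4 (0.26 log units; within the scatter).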

Compound 4, half-maximal inhibitory concentration: 35200 nM
The estimate for compound 4 lay 2.3-fold (0.37 log units) below the measured number; measured number inside the range.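

In this assay, for the compounds shown here, the change from 4-methoxyphenyl to cyclopropyl on the amide-type nitrogen gives the first step of readable size at this position: a 4.3-fold higher number from compound 2 to compound 4 (0.63 log units; beyond the scatter). It shows that this nitrogen's group can shift the number, and that here the shift runs towards weaker inhibition. The only other step at this position still cannot be read, since both of its ends sit at a limit: the limit of > 40000 nM in this assay, at which 2 of the 4 values shown sit.

One step replaces an aromatic ring with a much smaller non-aromatic one, so the compounds shown do not separate these two changes. Going by these compounds, how an unsubstituted phenyl or a longer chain such as n-butyl on this nitrogen would read remains open.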